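The compounds below may be only part of what the source reports. "The series", "measured", "known", "first", "only" and "open" are said of these compounds alone.

Measured compounds:

Compound 1, `CN(C)CN1C(=O)C(=O)c2c(Br)cccc21`, gives 67800 nM.
Compound 2, `O=C1C(=O)N(CN2CCCCC2)c2cccc(Br)c21`, gives 66900 nM.
Compound 3, `Cc1ccc2nc(/N=C3\C(=O)N(CN(C)C)c4cccc(Cl)c43)sc2c1`, gives 7020 nM.

All three values come from an ADME assay on MCF-10A cells (Homo sapiens) for cytotoxicity, read by sulforhodamine B assay, with a stated time of 48 h; on this read-out lower numbers stand for stronger inhibition of growth and higher numbers for weaker inhibition of growth. Compound 1 and compound 2 share one core and differ only by piperidin-1-yl in place of dimethylamino on a saturated chain carbon bound to an amide-type nitrogen in a ring. The step between them is a 1.0-fold lower number from compound 1 to compound 2 (0.01 log units; within the scatter), so the two values cannot be told apart, and neither compound can be called the stronger growth inhibitor. Compound 3 carries a different core, and how that core differs from the core of compound 1 is not broken down here. In this assay compound 3 gives the lowest number of the three, and its distance from both compound 1 and compound 2 lies beyond the usual scatter.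

Compound 4, `Cc1ccc2nc(/N=C3\C(=O)N(CN4CCCCC4)c4cccc(Cl)c43)sc2c1`, has not yet been measured in this assay. It differs from compound 3 by piperidin-1-yl in place of dimethylamino on a saturated chain carbon bound to an amide-type nitrogen in a ring, the same change, at the same place, that separates compound 1 from compound 2. The expected step from compound 3 to compound 4 is a 1.0-fold lower number from compound 3 to compound 4 (0.00 log units; within the scatter), a small one, because a 1.0-fold lower number from compound 1 to compound 2 (0.01 log units; within the scatter) showed this change leaving the value essentially unchanged on the other core. Compound 4 is therefore estimated at 7000 nM in this assay, with a likely range from 3500 nM to 14000 nM.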

Compound 4, concentration for 50% growth inhibition: 30200 nM
The estimate for compound 4 lay 4.3-fold (0.63 log units) below the measured number; measured number above the stated range.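

In this assay, the swap of dimethylamino for piperidin-1-yl raises the number on the core of compound 3, which means weaker inhibition of growth: the change gives a 4.3-fold higher number from compound 3 to compound 4 (0.63 log units; beyond the scatter). Set beside the earlier step on the core of compound 1, this shows that the same change at the same place does not carry the same result from one core to the other, so a step seen on one core is a poor guide to the step on another in this series: the same change on two cores in this assay, a 1.0-fold lower number (0.01 log units; within the scatter) from compound 1 to compound 2 and a 4.3-fold higher number (0.63 log units; beyond the scatter) from compound 3 to compound 4, 4.4-fold (0.64 log units) apart, beyond the scatter of two such steps

For the compounds shown here, what this does not show is which feature of the two cores makes the difference, since they are not broken down into single changes, and it rests on only two matched pairs, which is too few to reveal any general rule.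

The compounds shown leave open how other amines at this place would behave on each core, for example pyrrolidin-1-yl, morpholin-4-yl or diethylamino. They also leave open whether bromo in place of chloro on the core of compound 3 would alter the size of the step, or whether the larger part of that core decides it.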